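Clearance series: ester, acid, and the anilide to come

The compounds below may be only part of what the source reports. "The series", "measured", "known", "first", "only" and "open" are said of these compounds alone.

Measured so far:
compound 1 `CCOC(=O)c1cc(-c2csc(Nc3ccc(C)cc3)n2)on1` — > 400 mL/min/kg
compound 2 `CCOC(=O)c1cc(-c2csc(Nc3cc(Cl)cc(Cl)c3)n2)on1` — 189 mL/min/kg
compound 3 `Cc1ccc(Nc2nc(-c3cc(C(=O)O)no3)cs2)cc1` — 43.7 mL/min/kg

In an ADME assay on microsomes from liver (Homo sapiens) for metabolic stability, read by LC-MS, tested at 1 uM (a higher number here means faster removal of the compound, a lower number slower removal), compound 1 sits at a limit of the assay, > 400 mL/min/kg, and gives no number (the limit of > 400 mL/min/kg in this assay, at which 1 of the 3 values shown sits). Compound 2 gives 189 mL/min/kg in this assay. Compound 3 gives 43.7 mL/min/kg in this assay, the lowest number of the two numbers shown; the nearest, compound 2, stands a good deal higher.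

Two steps have been measured from compound 1. Exchanging the aryl group on the nitrogen gives an at least 2.1-fold lower number from compound 1 to compound 2 (0.32 log units; beyond the scatter). Removing the ethyl from the oxygen of the ester gives an at least 9.1-fold lower number from compound 1 to compound 3 (0.96 log units; beyond the scatter); the acid is the slowest-cleared member.

Compound 4 `Cc1ccc(Nc2nc(-c3cc(C(=O)Nc4ccccc4)no3)cs2)cc1` is the next to be measured. Its difference from compound 3 is anilino in place of hydroxy on a carbonyl carbon. For the measured compounds named here, no measured step covers this change. Going by the values given here, the only step touching the carbonyl group, from compound 1 to compound 3, shows the acid clearing more slowly than the ester; compound 4 gives that acid up for an anilide, so a step back upward in this assay is the expectation, of the order of a 2.7-fold higher number from compound 3 to compound 4 (0.44 log units; beyond the scatter). For compound 4 the number expected in this assay is 120 mL/min/kg, with a range from 45 mL/min/kg to 320 mL/min/kg.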

Compound 4, clearance: 17.8 mL/min/kg
For compound 4 the middle estimate is 6.7-fold (0.83 log units) above the measured one; the whole stated range lies above it.
By their numbers in this assay, from the lowest: compound 4; then compound 3; then compound 2. At a limit, above all of these: compound 1.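

In this assay the carbonyl carbon takes anilino in place of hydroxy with a 2.5-fold lower number from compound 3 to compound 4 (0.39 log units; beyond the scatter) and the number keeps falling, so the carboxylic acid of compound 3 does not mark the low end at this place, and a free carboxy group is not needed for slow removal here. Set against the ethyl ester, anilino in place of ethoxy gives an at least 22-fold lower number from compound 1 to compound 4 (1.35 log units; beyond the scatter) and thus joins hydroxy as a second replacement of ethoxy that lowers the number, with the phenylcarbamoyl group carrying the lowest value of the series so far. Compound 1 stands at a limit, so the size of this step is a bound and not a measured gap: the limit of > 400 mL/min/kg in this assay, at which 1 of the 4 values shown sits.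

As far as these compounds go, it remains open whether the phenyl ring of the anilino group or the amide itself accounts for the step, which an amide from methylamine or morpholine on the same carbonyl carbon would separate. It also remains open whether the step carries over to the 3,5-dichlorophenyl group of compound 2, and nothing shown gives a reason for the step.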